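From phenyl to 2-cyclopropylethynyl on the shared core

The compounds below may be only part of what the source reports. "The series", "measured", "known", "first", "only" and "open" are said of these compounds alone.

Compound 1 `CC1Cn2c(nc([N+](=O)[O-])c2-c2ccc(Cl)cc2)O1`: > 250000 nM (a limit)
Compound 2 `CC1Cn2c(nc([N+](=O)[O-])c2-c2ccccc2)O1`: > 500000 nM (a limit)

In an ADME assay on CHO cells (Cricetulus griseus) for cytotoxicity, read by MTT assay, with a stated time of 24 h (on this read-out lower numbers stand for higher toxicity in this test and higher numbers for lower toxicity in this test), compound 2 stands at > 500000 nM, which is a limit and not a number. Compound 3 `CC1Cn2c(nc([N+](=O)[O-])c2C#CC2CC2)O1` differs from it as follows: 2-cyclopropylethynyl in place of phenyl on an aromatic carbon. Among the measured compounds shown here, the only measured step, a step that the two limits leave unreadable from compound 1 to compound 2, gives no size to carry over, so the data support no firm direction. The expected step, read against the limit of compound 2, is an at least 1.2-fold lower number from compound 2 to compound 3 (0.09 log units; that floor lies within the scatter). Compound 3 is expected near 400000 nM, with an estimated range of 120000 nM to 700000 nM.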

Compound 3, half-maximal cytotoxic concentration: 6450 nM
Compound 3: the middle estimate sits 62-fold (1.79 log units) above what was measured; measured number below the stated range.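

In this assay, this position on the shared core proves able to move the read-out: 2-cyclopropylethynyl in place of phenyl gives an at least 77-fold lower number from compound 2 to compound 3 (1.88 log units; beyond the scatter). Among the compounds shown here, the earlier step from chloro to hydrogen cannot be read, so compound 3 supplies the first real number. Compound 2 stands at a limit, so the size of this step is only a floor: the limit of > 500000 nM in this assay, at which 1 of the 3 values shown sits.

The compounds shown leave open whether the lower number goes with the triple bond or with the three-membered ring. They also leave open how a plain alkyl chain or an amine would read at this position.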